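A urea cap on a piperidine fragment for EED

This account rests on a few compounds, and the source may have more. Where it says the series, first, only, none or still open, it means among the compounds named here.

Of the compounds shown here, three have been measured in an assay for inhibition of Polycomb protein EED (Homo sapiens), read by LC-MS, with a stated time of 2 h; on this read-out higher numbers stand for weaker inhibition and lower numbers for stronger inhibition. Compound 1 `COc1ccc(CC2CCCNC2)cc1` reaches only the limit of the assay, > 500000 nM, so no number is known for it. Compound 2 `c1cc(CC2CCCNC2)c2occc2c1` gives 95000 nM, the higher of the two numbers shown. Compound 3 `c1cc(CC2CCCNC2)c2ccoc2c1` gives 40000 nM, a lower value than compound 2 by more than the usual scatter. Compound 4 `NC(=O)N1CCCC(Cc2cccc3ccoc23)C1` differs from compound 2 by carbamoyl in place of hydrogen on an amine nitrogen in a ring. Among the measured compounds shown here, no step between measured compounds in this assay shows what such a change does, so any expectation rests on compound 2 alone. The expected step from compound 2 to compound 4 is a 1.1-fold higher number from compound 2 to compound 4 (0.02 log units; within the scatter), no larger than the scatter in either direction. Compound 4 is therefore estimated at 100000 nM, within a range from 30000 nM to 400000 nM.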

Compound 4, half-maximal inhibitory concentration: 174000 nM
Compound 4: the middle estimate sits 1.7-fold (0.24 log units) below what was measured, within the range that was stated.
By their numbers in this assay, from the lowest: compound 3; then compounds 2 and 4 (each within the scatter of the next). At a limit, above all of these: compound 1.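

Carbamoyl in place of hydrogen on an amine nitrogen in a ring gives a 1.8-fold higher number from compound 2 to compound 4 (0.26 log units; within the scatter) in this assay, so this position accepts the group with no change beyond the scatter. Compound 4 also gives a measured number rather than a limit of the assay: the limit of > 500000 nM in this assay, at which 1 of the 4 values shown sits.

On these data alone, whether a different group on this nitrogen, such as acetyl, methyl or a longer chain ending in an amine, would move the number beyond the scatter remains open. So does the effect of carbamoyl on the core of compound 3.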